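A Urea Pair Weighed Before a Cyclohexyl Replacement

This account rests on a few compounds, and the source may have more. Where it says the series, first, only, none or still open, it means among the compounds named here.

Compound 1 `Cc1ccc(NC(=O)N(Cc2ccccn2)n2cnnc2)cc1` and compound 2 `COc1cc(CN(C(=O)Nc2ccc(C)cc2)n2cnnc2)cc(OC)c1OC` share a urea core carrying a triazole on one nitrogen. Among the measured compounds shown here, in a functional assay on MCF7 cells (Homo sapiens) for cytotoxicity, read by MTT assay, with a stated time of 48 h (a lower number here means a stronger inhibitor, a higher number a weaker inhibitor), compound 1 gives 38900 nM, and it stands as the only outright number in this set. Compound 2 reaches only the limit of the assay, > 50000 nM. Part of what is reported therefore sits at the limit of > 50000 nM in this assay, at which 1 of the 2 values shown sits, so no measured step between the two can be drawn.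

Compound 3 `O=C(NC1CCCCC1)N(Cc1ccccn1)n1cnnc1` is not yet measured. It differs from compound 1 by cyclohexyl in place of 4-methylphenyl on an amide-type nitrogen. For the measured compounds named here, with no measured step to lean on, the account can only note that the starting point is weak and expect the change to leave the number near or beyond the scatter toward weaker, so that the step of a 1.2-fold higher number from compound 1 to compound 3 (0.06 log units; within the scatter) is estimated as modest. Compound 3 is expected to give about 45000 nM, within a range from 15000 nM to 120000 nM.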

Compound 3, half-maximal inhibitory concentration: 46900 nM
The estimate for compound 3 lay 1.0-fold (0.02 log units) below the measured number; the measured number falls inside the stated range.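

In this assay, among the compounds shown here, cyclohexyl in place of 4-methylphenyl on an amide-type nitrogen gives a 1.2-fold higher number from compound 1 to compound 3 (0.08 log units; within the scatter) and provides the first measured step in this set. For this pair, therefore, an aromatic and a non-aromatic six-membered carbon ring cannot be told apart at this place, and the change opens no route to a stronger compound. Nothing measured here gives a cause for this result.

For the compounds shown here, compound 2 stands at a limit of the assay, > 50000 nM and no step to it can be read. As far as these compounds go, it remains open whether an amine on the cyclohexyl ring, or an open chain such as n-hexyl in its place on this amide-type nitrogen, would move the number beyond the scatter.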